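This account rests on a few compounds, and the source may have more. Where it says the series, first, only, none or still open, it means among the compounds named here.

Compound 3 `Cc1cc(Nc2cc(-c3ccccc3)[nH]n2)n2nc(SCc3ccccc3Br)nc2n1` gives 3020 nM in a functional assay on MCF7 cells (Homo sapiens) for inhibition, read by MTT assay, with a stated time of 72 h (on this read-out higher numbers stand for weaker inhibition and lower numbers for stronger inhibition), the smallest of the three numbers shown, while compound 1 `Cc1cc(Nc2cc(-c3ccccc3)[nH]n2)n2nc(SCCCc3ccccc3)nc2n1` gives 3900 nM and compound 2 `Cc1cc(Nc2cc(-c3ccccc3)[nH]n2)n2nc(SCc3ccc(C(F)(F)F)cc3)nc2n1` gives 4820 nM, both within the scatter of compound 3. Compound 4 `COc1ccc(CSc2nc3nc(C)cc(Nc4cc(-c5ccccc5)[nH]n4)n3n2)cc1` differs from compound 3 by 4-methoxyphenyl in place of 2-bromophenyl on a saturated chain carbon bound to a sulfur. The steps already measured at this position bear on it: a 1.3-fold lower number from compound 1 to compound 3 (0.11 log units; within the scatter), a 1.6-fold lower number from compound 2 to compound 3 (0.20 log units; within the scatter) and a 1.2-fold higher number from compound 1 to compound 2 (0.09 log units; within the scatter), none beyond the scatter. Each exchange of the group on the saturated chain carbon bound to a sulfur has so far left this assay essentially unmoved, so the step of a 1.2-fold higher number from compound 3 to compound 4 (0.08 log units; within the scatter) is expected to remain within the scatter. Compound 4 is therefore estimated at 3600 nM, with a range of 1800 nM to 7200 nM.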

Compound 4, half-maximal inhibitory concentration: 4020 nM
Compound 4: the middle estimate sits 1.1-fold (0.05 log units) below what was measured; the measured number falls inside the stated range.
By their numbers in this assay, from the lowest: compounds 3, 1, 4 and 2 (each within the scatter of the next).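

In this assay, 4-methoxyphenyl brings the first hydrogen-bond acceptor to the group on a saturated chain carbon bound to a sulfur, yet the exchange for 2-bromophenyl stays within the scatter (a 1.3-fold higher number from compound 3 to compound 4 (0.12 log units; within the scatter)), as does the exchange for phenethyl (a 1.0-fold higher number from compound 1 to compound 4 (0.01 log units; within the scatter)). Methoxy in place of trifluoromethyl on an aromatic carbon, a swap of one substituent on the same ring, also stays within the scatter (a 1.2-fold lower number from compound 2 to compound 4 (0.08 log units; within the scatter)). No measured evidence accounts for this flatness.

Open, as far as these compounds go, is whether an amine or a carboxylic acid on that ring would move the number beyond the scatter. A plain alkyl chain with no aromatic ring at this position also remains untested among the compounds shown.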